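Second Methyl on the Aryl Ring of Compound 1

The source may hold more compounds than are shown below. What is called first, only, known or untested is meant among the compounds shown, and "the series" means these compounds.

Compound 1 `CCC1=C(O)c2c(oc(-c3cccc(C)c3)cc2=O)C(CC)(CC)C1=O` was tested in a functional assay on KB cells (Homo sapiens) for antiproliferative activity, read by sulforhodamine B assay, with a stated time of 3 days (on this read-out higher numbers stand for an effect only at larger amounts of compound and lower numbers for an effect already at smaller amounts), and gives 49.7 uM. Compound 2 `CCC1=C(O)c2c(oc(-c3cc(C)c(OC)cc3C)cc2=O)C(CC)(CC)C1=O` gives 36.6 uM in this assay; this number and that of compound 1 lie within the usual scatter of each other, so the two compounds cannot be told apart. Compound 3 `CCC1=C(O)c2c(oc(-c3cccc(C)c3C)cc2=O)C(CC)(CC)C1=O` differs from compound 1 by a single change: methyl in place of hydrogen on an aromatic carbon. Among the compounds with values here, no pair of measured compounds shows a change of this kind, so nothing measured points to a direction. The step from compound 1 to compound 3 is expected to be small, a 1.2-fold lower number from compound 1 to compound 3 (0.09 log units; within the scatter), and not beyond the scatter. Compound 3 is therefore estimated at 40 uM, between 15 uM and 110 uM.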

Compound 3, concentration for half-maximal effect: 3.1 uM
Estimate against measurement, compound 3: 13-fold (1.11 log units) above, outside the stated range (below it).
By their numbers in this assay, from the lowest: compound 3; then compounds 2 and 1 (each within the scatter of the next).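

In this assay, a single added methyl, ortho to a large group and ortho to a methyl group, gives a 16-fold lower number from compound 1 to compound 3 (1.20 log units; beyond the scatter) and so moves the number beyond the scatter. Within the data shown here, this place on the aromatic ring therefore responds strongly to a change of just one heavy atom, something no earlier pair could show. No measurement available gives a reason for this step. Going by these compounds, whether an amine or a chlorine atom at this place would give a similar step stays open. So does whether the methyl group already present in compound 1 is needed for the step.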